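Working notes: replacing heptyl in compound 3

The source may hold more compounds than are shown below. What is called first, only, known or untested is meant among the compounds shown, and "the series" means these compounds.

compound 1 `CCCCOC(=O)OCCc1ccc(O)c(O)c1`: "not determined" (no result reported)
compound 2 `CCCCCCOC(=O)OCCc1ccc(O)c(O)c1`: 11200 nM
compound 3 `CCCCCCCCCOC(=O)OCCc1ccc(O)c(O)c1`: 15900 nM
compound 4 `O=C(OCCc1ccc(O)c(O)c1)OCCc1ccc(O)c(O)c1`: not yet measured

In an ADME assay on MRC5 cells (Homo sapiens) for inhibition, read by MTT assay, with a stated time of 72 h (a lower number here means a stronger inhibitor, a higher number a weaker inhibitor), only compound 2 and compound 3 have numbers, and these lie within the scatter of each other. The next change is 3,4-dihydroxyphenyl in place of heptyl on a saturated chain carbon, two bonds along the chain from an oxygen next to a carbonyl group. Going by the values given here, the only measured step bearing on it is a 1.4-fold higher number from compound 2 to compound 3 (0.15 log units; within the scatter). Among the compounds with values here, that step concerns chain length alone, and no measured step puts a ring at this place, so it is a weak guide. No step beyond the scatter is expected in this assay, in either direction, but the uncertainty is wide. The expected step is a 1.1-fold lower number from compound 3 to compound 4 (0.03 log units; within the scatter). For compound 4 the estimated value is 15000 nM, with an expected range of 5000 nM to 50000 nM.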

Compound 4, half-maximal inhibitory concentration: > 50000 nM
Compound 4 was reported as a limit; the forecaster's own chance of this, stated with the estimate: 15%; middle value at least 3.3-fold (0.52 log units) away from the limit.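

In this assay, 3,4-dihydroxyphenyl at this place gives an at least 3.1-fold higher number from compound 3 to compound 4 (0.49 log units; beyond the scatter) and an at least 4.4-fold higher number from compound 2 to compound 4 (0.64 log units; beyond the scatter). Going by these compounds alone, the only earlier step, a change of chain length, stayed within the scatter, so this is the first change to give a weaker inhibitor beyond it. Compound 4 stands at a limit of the assay, not at a number: the limit of > 50000 nM in this assay, at which 1 of the 4 values shown sits.

On these data alone, how far compound 4 lies past that limit stays open. Also open, as far as these compounds go, is whether the ring or its hydroxyl groups carry the step, which a plain phenyl at this place would separate, and how an amine there would read.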